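This account rests on a few compounds, and the source may have more. Where it says the series, first, only, none or still open, it means among the compounds named here.

Compound 1 `C/C=C1/[C@H](O[C@@H]2O[C@H](CO)[C@@H](O)[C@H](O)[C@H]2O)OC=C(C(=O)OC)[C@H]1CC(=O)OCC`: > 15000 nM (a limit)
Compound 2 `C/C=C1/[C@H](O[C@@H]2O[C@H](CO)[C@@H](O)[C@H](O)[C@H]2O)OC=C(C(=O)OC)[C@H]1CC(=O)OCCC(C)C`: 9020 nM
Compound 3 `C/C=C1/[C@H](O[C@@H]2O[C@H](CO)[C@@H](O)[C@H](O)[C@H]2O)OC=C(C(=O)OC)[C@H]1CC(=O)OCc1ccccc1`: not yet measured

All values come from a functional assay on SK-BR-3 cells (Homo sapiens) for antiproliferative activity, read by MTT assay, with a stated time of 72 h; a higher number here means a weaker inhibitor, a lower number a stronger inhibitor. The entry for compound 1 is a limit of the assay, not a number. Among the compounds with values here, compound 2 gives 9020 nM, the only number so far. The next change is phenyl in place of isobutyl on a saturated chain carbon bound to an oxygen next to a carbonyl group. Within the data shown here, the one measured step, an at least 1.6-fold lower number from compound 1 to compound 2 (0.22 log units; that floor lies within the scatter), also falls on this chain but gives only a floor, so no step beyond the scatter is expected. The estimated step is a 1.1-fold lower number from compound 2 to compound 3 (0.05 log units; within the scatter). Compound 3 is expected near 8000 nM, within an estimated range of 3500 nM to 15000 nM.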

Compound 3, half-maximal inhibitory concentration: > 15000 nM
Compound 3 gave a limit, no number (the forecaster's own chance of this, stated with the estimate: 30%); middle value at least 1.8-fold (0.27 log units) away from the limit.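

In this assay compound 3 gives > 15000 nM, a limit of the assay and not a number. Benzyl in place of isopentyl gives an at least 1.6-fold higher number from compound 2 to compound 3 (0.22 log units; that floor lies within the scatter), so this aromatic ring at this place yields no second number, and compound 2 remains the only compound with a measured value, though the floor does not separate it from compound 3. The step from compound 1 to compound 3 cannot be read, and most of the series rests at one ceiling: the limit of > 15000 nM in this assay, at which 2 of the 3 values shown sit.

On these data alone, whether a longer chain or an amine at this place gives a number clearly apart from that of compound 2 stays open.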